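Amine substituent variation on the shared core: cytotoxicity notes

The source may report more compounds than this note shows. Statements on the series, on what has been measured and on what is new or still open speak of the compounds shown alone.

Measured compounds:
- compound 1 `FC(F)(F)c1ccc(CSc2nc(N3CCCCC3)c3ccccc3n2)cc1`; in a functional assay on HGC-27 cells (Homo sapiens) for cytotoxicity, read by MTT assay, with a stated time of 72 h (a lower number here means a stronger inhibitor, a higher number a weaker inhibitor), compound 1 gives > 50000 nM, a limit of the assay.
- compound 2 `FC(F)(F)c1ccc(CSc2nc(Nc3ccccc3Cl)c3ccccc3n2)cc1`; in this assay compound 2 gives > 50000 nM, likewise only a limit.
- compound 3 `O=[N+]([O-])c1cccc(Nc2nc(SCc3ccc(C(F)(F)F)cc3)nc3ccccc23)c1`; in this assay compound 3 gives > 50000 nM, again a limit.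

Compound 2 therefore stands nowhere in particular on the numbers shown: every value in this set is a limit, as the limit of > 50000 nM in this assay, at which 3 of the 3 values shown sit, records, and none is a number. The steps a step that the two limits leave unreadable from compound 1 to compound 2, a step that the two limits leave unreadable from compound 1 to compound 3 and a step that the two limits leave unreadable from compound 2 to compound 3 are all unreadable for that reason, so neither direction nor size of any change can be taken from them.

Compound 4 `COc1ccc(Nc2nc(SCc3ccc(C(F)(F)F)cc3)nc3ccccc23)cc1OC` is the next member. It differs from compound 2 as follows: 3,4-dimethoxyphenyl in place of 2-chlorophenyl on a nitrogen on an aromatic ring. Among the compounds with values here, no measured step bears on this change in a readable way; the only evidence is that three different amine substituents on the core all sit at the limit. The expectation for the step that the limit leaves unreadable from compound 2 to compound 4 is therefore no readable movement, with a substantial chance of another limit. Compound 4 is estimated at 60000 nM, within 10000 nM to 300000 nM.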

Compound 4, half-maximal inhibitory concentration: 17900 nM
For compound 4 the middle estimate is 3.4-fold (0.53 log units) above the measured one; the range from low to high includes it.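

In this assay, the amine substituent on the shared core proves able to shift the read-out: 3,4-dimethoxyphenyl in place of 2-chlorophenyl on the nitrogen gives an at least 2.7-fold lower number from compound 2 to compound 4 (0.44 log units; beyond the scatter), and 3,4-dimethoxyphenyl in place of 3-nitrophenyl gives an at least 2.7-fold lower number from compound 3 to compound 4 (0.44 log units; beyond the scatter). Measured against the piperidin-1-yl group, the (3,4-dimethoxyphenyl)amino group gives an at least 2.7-fold lower number from compound 1 to compound 4 (0.44 log units; beyond the scatter). Each of these steps is a minimum size only, because compound 4 alone among the members shown has a number rather than a limit: the limit of > 50000 nM in this assay, at which 3 of the 4 values shown sit.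

The steps among compound 1, compound 2 and compound 3 cannot be read, so those three remain unranked. Also open, from the compounds shown here alone, is whether a phenyl ring carrying a single methoxy group, or hydroxyl groups in place of the two methoxy groups, would give the same shift.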